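Cytotoxicity in the shared core: the step from compound 2 to compound 3

This account rests on a few compounds, and the source may have more. Where it says the series, first, only, none or still open, it means among the compounds named here.

Compound 1 `CN(C)c1ccc2nc(-c3c(Cl)nc(N)nc3N[C@@H]3C[C@H](CO)[C@@H](O)[C@H]3O)sc2c1` — in an ADME assay on cells (Homo sapiens) for cytotoxicity, read by polymerase chain reaction, with a stated time of 3 days (a higher number here means that more compound is tolerated, a lower number that less compound is tolerated), compound 1 sits at the assay limit, > 25000 nM.
Compound 2 `Cc1nc(NC(C)C)nc(N[C@@H]2C[C@H](CO)[C@@H](O)[C@H]2O)c1-c1nc2ccccc2s1` — in this assay compound 2 gives 13000 nM.

Among the measured compounds shown here, compound 2 carries the only number reported in this assay for the series; the other value recorded is a limit rather than a number, (the limit of > 25000 nM in this assay, at which 1 of the 2 values shown sits). Nothing can therefore be said about the size of any measured step in this assay, and compound 2 stands alone as the reference point.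

Compound 3 `CCOCCNc1nc(C)c(-c2nc3ccccc3s2)c(N[C@@H]2C[C@H](CO)[C@@H](O)[C@H]2O)n1` is built on the same core as compound 2 and differs from it in one place: 2-ethoxyethyl in place of isopropyl on a nitrogen on an aromatic ring. For the measured compounds named here, no pair of measured compounds covers this change, so there is no measured step to lean on. The expectation is a small change, within the usual scatter, in this assay, with the step from compound 2 to compound 3 estimated as a 1.2-fold higher number from compound 2 to compound 3 (0.06 log units; within the scatter). Compound 3 is accordingly expected to give about 15000 nM in this assay, with a range from 6000 nM to 40000 nM.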

Compound 3, half-maximal cytotoxic concentration: 18000 nM
For compound 3 the middle estimate is 1.2-fold (0.08 log units) below the measured one, within the range that was stated.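

Cytotoxicity notes, this position: the series now has its first measured step in one place in this assay, and it reads a 1.4-fold higher number from compound 2 to compound 3 (0.14 log units; within the scatter). On a nitrogen on an aromatic ring, isopropylamino and (2-ethoxyethyl)amino are therefore not told apart by this read-out, even though the entering chain has 5 heavy atoms and 1 hydrogen-bond acceptor against 3 heavy atoms and 0 hydrogen-bond acceptors in the group that leaves. Compound 2 is no longer the lone reference point, but compound 1 remains a limit rather than a number, and any step to it cannot be read: the limit of > 25000 nM in this assay, at which 1 of the 3 values shown sits.

As far as these compounds go, whether a longer chain, or a chain bearing an amine or a carboxylic acid, gives a step beyond the scatter in the same place in this assay stays open. From the compounds shown here alone, with a single pair on the shared core, it also stays open whether the same exchange reads alike when other parts of the core differ, as they do in compound 1.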